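Chloro to nitro on the highest-reading compound

The source may hold more compounds than are shown below. What is called first, only, known or untested is meant among the compounds shown, and "the series" means these compounds.

In a functional assay, with a stated time of 30 min (on this read-out higher numbers stand for weaker inhibition and lower numbers for stronger inhibition), compound 2 `CCCCc1oc2ccc(/N=C/c3ccc(Cl)cc3)cc2c1C(=O)c1ccc(OC)cc1` gives 75.9 ug/mL and stands highest of the three measured compounds. Compound 1 `CCCCc1oc2ccc(/N=C/c3cccc([N+](=O)[O-])c3)cc2c1C(=O)c1ccc(OC)cc1` gives 34.2 ug/mL and compound 3 `CCCCc1oc2ccc(/N=C/c3ccccc3)cc2c1C(=O)c1ccc(OC)cc1` gives 34.2 ug/mL with no difference between them. Among the compounds with values here, compound 4 `CCCCc1oc2ccc(/N=C/c3ccc([N+](=O)[O-])cc3)cc2c1C(=O)c1ccc(OC)cc1` is not yet measured and has nitro in place of chloro on an aromatic carbon, para to a large group nitro in place of chloro on an aromatic carbon as its one change from compound 2. Within the data shown here, two measured steps bear on this. Hydrogen in place of chloro gave a 2.2-fold lower number from compound 2 to compound 3 (0.35 log units; beyond the scatter) and hydrogen in place of the nitro of the 3-nitrophenyl group gave no change at the digits printed from compound 1 to compound 3 (within the scatter) but that nitro is not the 4-nitrophenyl case. A modest step toward stronger inhibition is therefore expected a 2.0-fold lower number from compound 2 to compound 4 (0.30 log units; within the scatter) in this read-out. The estimate for compound 4 is 38 ug/mL with 18 ug/mL to 80 ug/mL as the expected range.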

Compound 4, half-maximal inhibitory concentration: 53.1 ug/mL
Compound 4: middle estimate off by 1.4-fold (0.15 log units), on the low side, and the stated range covers the measured number.
By their numbers in this assay, from the lowest: compounds 1, 3, 4 and 2 (each within the scatter of the next, the first and the last beyond it).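

In this assay, nitro in place of chloro gives a 1.4-fold lower number from compound 2 to compound 4 (0.16 log units; within the scatter), so at this position the 4-nitrophenyl and 4-chlorophenyl compounds cannot be told apart. The nitro compound also stays close to its hydrogen counterpart, with a 1.6-fold higher number from compound 3 to compound 4 (0.19 log units; within the scatter), and 4-nitrophenyl in place of 3-nitrophenyl gives a 1.6-fold higher number from compound 1 to compound 4 (0.19 log units; within the scatter), so among these compounds only chloro stands beyond the scatter from hydrogen, and nitro in either place does not. No evidence accompanies these numbers that could explain them.

As far as these compounds go, whether an amine or a carboxylic acid at this position would read apart from hydrogen remains open.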